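A few compounds are considered here, and "the series" means these few. Any claim that something is new, unique, unknown or untested is made for them only; others in the source may bear on it.

In an ADME assay on microsomes from liver (Homo sapiens) for metabolic stability, with a stated time of 10 min (a lower number here means that less of the compound is left, a higher number that more of the compound is left), compound 1 `O=C(N1CC[C@](c2ccc(C(F)(C(F)(F)F)C(F)(F)F)cc2)(S(=O)(=O)c2ccc(F)cc2)C1)C12CCC(C(=O)O)(CC1)OC2` stands at "not determined" (no result reported), so the starting point of this step has no number. The only figures on the shared core come from compound 2 `O=C1NC(=O)C2(CCC(C(=O)N3CC[C@](c4ccc(C(F)(C(F)(F)F)C(F)(F)F)cc4)(S(=O)(=O)c4ccc(F)cc4)C3)CC2)N1`, which gives 84%; 93% (2 entries). Compound 3 `O=C([C@H]1CC[C@H](CO)CC1)N1CC[C@](c2ccc(C(F)(C(F)(F)F)C(F)(F)F)cc2)(S(=O)(=O)c2ccc(F)cc2)C1` differs from compound 1 by a group of 8 heavy atoms (7 carbon, 1 oxygen; one six-membered non-aromatic ring of carbon only) in place of a group of 11 heavy atoms (8 carbon, 3 oxygen; one six-membered non-aromatic ring of carbon only, one six-membered non-aromatic ring with 1 hetero atom), on a carbonyl carbon, with 4-(hydroxymethyl)cyclohexyl now on the carbonyl carbon. Among the compounds with values here, no measured step shows what such a change does, so no shift beyond the scatter is expected in this assay, and compound 2 at 84%; 93% (2 entries) remains the sole anchor. For compound 3 the expected value is 78%, within an estimated range of 52% to 95%.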

Compound 3, percent of the compound remaining: 75%
The estimate for compound 3 lay 3 percentage points above the measured number, and the stated range covers the measured number.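

Compound 1 and compound 3 give no readable step in this assay, as compound 1 has no number there. The effect of 4-(hydroxymethyl)cyclohexyl on the carbonyl carbon stays open, and nothing shown bears on the result for compound 3.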